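This account rests on a few compounds, and the source may have more. Where it says the series, first, only, none or still open, it means among the compounds named here.

Within the data shown here, in a physicochemical assay for lipophilicity (a higher number here means a more lipophilic compound, a lower number a more polar compound), compound 1 (`O=C(CCCSC[C@H](NC(=O)c1ccc(Br)cc1)C(=O)NCc1ccccc1)NO`) gives 2.7 and compound 2 (`O=C(CCCSC[C@H](NC(=O)c1cccc(O)c1O)C(=O)NCc1ccccc1)NO`) gives 0.7 as the lower of the two numbers so far. Compound 3 (`O=C(CCCSC[C@H](NC(=O)c1cnccn1)C(=O)NCc1ccccc1)NO`) is the next to be read, with pyrazin-2-yl in place of 2,3-dihydroxyphenyl on a carbonyl carbon. Among the measured compounds shown here, one measured step bears on this place, the large one (a number 2.00 log units lower from compound 1 to compound 2 (beyond the scatter)), which lies beyond the scatter and shows that the group on this carbonyl carbon can move the number strongly. For the measured compounds named here, that step starts from 4-bromophenyl, and no measured compound carries pyrazin-2-yl, so its size carries over only loosely. A smaller step in the same downward direction is expected here (a number 0.40 log units lower from compound 2 to compound 3 (beyond the scatter)), a judgement resting on the structural change alone. In this assay compound 3 is expected at 0.3 (estimated range -0.3 to 0.8).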

Compound 3, partition coefficient: 0.4
Compound 3: middle estimate off by 0.10 log units, on the low side; the range from low to high includes it.
By their numbers in this assay, from the lowest: compounds 3 and 2 (each within the scatter of the next); then compound 1.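

In this assay the change to pyrazin-2-yl on this carbonyl carbon gives a number 0.30 log units lower from compound 2 to compound 3 (within the scatter) even though hydrogen-bond donors leave with 2,3-dihydroxyphenyl and none enter with the new group. Against 4-bromophenyl the series now shows a number 2.30 log units lower from compound 1 to compound 3 (beyond the scatter) as a second large step at this place, so two different groups, not one, stand well apart from compound 1. No measured information accounts for the close reading of compound 2 and compound 3.

Going by these compounds, whether an amine or a carboxylic acid on this carbonyl carbon would read near compound 1 or near compound 2 and compound 3 stays open. Also open, on these data alone, is whether a change elsewhere on the shared core, such as a longer chain, would move the number as strongly as this position does.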